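Chain extension on the amide across two anilino variants

The compounds below may be only part of what the source reports. "The series", "measured", "known", "first", "only" and "open" are said of these compounds alone.

Values in a functional assay on A549 cells (Homo sapiens) for antiproliferative activity, read by MTT assay, with a stated time of 72 h (on this read-out lower numbers stand for stronger inhibition and higher numbers for weaker inhibition), for the measured compounds:
compound 1, `C/C=C/C(=O)Nc1cccc(Oc2nc(Nc3cccc(C#N)c3)nc3c2CSCC3)c1`: 17200 nM
compound 2, `CC/C=C/C(=O)Nc1cccc(Oc2nc(Nc3cccc(C#N)c3)nc3c2CSCC3)c1`: 10100 nM
compound 3, `C/C=C/C(=O)Nc1cccc(Oc2nc(Nc3ccc(OC)nc3)nc3c2CSCC3)c1`: 8040 nM

Compound 1 and compound 2 differ by methyl in place of hydrogen on a saturated chain carbon bound to a double-bonded chain carbon; this gave a 1.7-fold lower number from compound 1 to compound 2 (0.23 log units; within the scatter). Compound 1 and compound 3 differ in their cores by 6-methoxypyridin-3-yl in place of 3-cyanophenyl on a nitrogen on an aromatic ring, which gave a 2.1-fold lower number from compound 1 to compound 3 (0.33 log units; beyond the scatter). Compound 4, `CC/C=C/C(=O)Nc1cccc(Oc2nc(Nc3ccc(OC)nc3)nc3c2CSCC3)c1`, is not yet measured; it differs from compound 3 by methyl in place of hydrogen on a saturated chain carbon bound to a double-bonded chain carbon, the same change seen from compound 1 to compound 2, made at the same place on the core of compound 3.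

For compound 4 in this assay a step of a 1.6-fold lower number from compound 3 to compound 4 (0.21 log units; within the scatter) is expected, resting on the earlier step of a 1.7-fold lower number from compound 1 to compound 2 (0.23 log units; within the scatter), which was within the scatter. Compound 4 is estimated at 5000 nM, with a likely range from 2500 nM to 10000 nM.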

Compound 4, half-maximal inhibitory concentration: 13100 nM
Compound 4: middle estimate off by 2.6-fold (0.42 log units), on the low side; measured number above the stated range.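

In this assay, the methyl in place of hydrogen on a saturated chain carbon gives a 1.6-fold higher number from compound 3 to compound 4 (0.21 log units; within the scatter), which does not match the earlier step on the other core: the same change on two cores in this assay, a 1.7-fold lower number (0.23 log units; within the scatter) from compound 1 to compound 2 and a 1.6-fold higher number (0.21 log units; within the scatter) from compound 3 to compound 4, 2.8-fold (0.44 log units) apart, beyond the scatter of two such steps. The exchange of 3-cyanophenyl for 6-methoxypyridin-3-yl, read with that methyl present, gives a 1.3-fold higher number from compound 2 to compound 4 (0.11 log units; within the scatter), and it too differs from its earlier counterpart: the same change on two cores in this assay, a 2.1-fold lower number (0.33 log units; beyond the scatter) from compound 1 to compound 3 and a 1.3-fold higher number (0.11 log units; within the scatter) from compound 2 to compound 4, 2.8-fold (0.44 log units) apart, beyond the scatter of two such steps. The methyl step therefore did not carry over unchanged between these two cores, but each methyl step alone lies within the scatter, so neither establishes a real effect of the methyl on its own core.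

Open, as far as these compounds go, is how a longer chain or an amine in place of that methyl would read on either core. Also open, from the compounds shown here alone, is whether the methyl step holds with other groups on that nitrogen.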